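The source may report more compounds than this note shows. Statements on the series, on what has been measured and on what is new or still open speak of the compounds shown alone.

Working notes on the series. Compound 1 `Cc1cc(Nc2cc(N3CCN(C)CC3)nc(Nc3ccc(S(N)(=O)=O)cc3)n2)n[nH]1`, compound 2 `Cc1cc(Nc2cc(N3CCN(C)CC3)nc(Nc3ccc(Cl)cc3)n2)n[nH]1` and compound 3 `COc1cccc(Nc2nc(Nc3cc(C)[nH]n3)cc(N3CCN(C)CC3)n2)c1` share a core and differ in the substituted phenyl on a nitrogen. In a functional assay on HL-60 cells (Homo sapiens) for antiproliferative activity, read by CCK-8 assay, with a stated time of 72 h (a higher number here means a weaker inhibitor, a lower number a stronger inhibitor), compound 3 gives 397 nM and compound 1 gives 213 nM. These two values cannot be separated, with a 1.9-fold higher number from compound 1 to compound 3 (0.27 log units; within the scatter). Compound 2 gives 83.4 nM, the lowest number of the three, and compound 3 lies clearly away from it, with a 4.8-fold higher number from compound 2 to compound 3 (0.68 log units; beyond the scatter).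

Compound 4 `Cc1cc(Nc2cc(N3CCN(C)CC3)nc(Nc3cccc([N+](=O)[O-])c3)n2)n[nH]1` has nitro in place of methoxy on an aromatic carbon, meta to a large group (nitro in place of methoxy on an aromatic carbon). Among the measured compounds shown here, no measured step makes this exact exchange, and none of the measured compounds carries nitro. The closest evidence is the other changes to the same phenyl. Compound 2 gives a 2.6-fold lower number from compound 1 to compound 2 (0.41 log units; beyond the scatter), a modest step, and the step between compound 2 and compound 3 quoted above is also modest. Across these compounds, changing the phenyl substituent has therefore moved the number by a modest amount or by nothing beyond the scatter, with no clear direction for the new group. A small step is expected, with no confident call on its direction. The expected change is a 1.4-fold lower number from compound 3 to compound 4 (0.15 log units; within the scatter). For compound 4 the estimate is 280 nM, with an expected range from 90 nM to 800 nM.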

Compound 4, half-maximal inhibitory concentration: 90.9 nM
Compound 4: middle estimate off by 3.1-fold (0.49 log units), on the high side; the range from low to high includes it.
By their numbers in this assay, from the lowest: compounds 2 and 4 (each within the scatter of the next); then compounds 1 and 3 (each within the scatter of the next).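

In this assay the exchange of methoxy for nitro on the same aromatic carbon, meta to a large group, gives a 4.4-fold lower number from compound 3 to compound 4 (0.64 log units; beyond the scatter) and is the first step shown that changes only the group at this place, so the identity of the group there is enough to move the number beyond the scatter. The new compound also separates from one earlier compound and not from the other: 3-nitrophenyl in place of 4-chlorophenyl gives a 1.1-fold higher number from compound 2 to compound 4 (0.04 log units; within the scatter) and cannot be told apart, while 3-nitrophenyl in place of 4-sulfamoylphenyl gives a 2.3-fold lower number from compound 1 to compound 4 (0.37 log units; beyond the scatter) and stands clear, a separation that the 3-methoxyphenyl of compound 3 did not show against compound 1. No measurement offered here accounts for the difference between nitro and methoxy at this carbon.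

As far as these compounds go, whether an amine, a nitrile or a carboxylic acid on the same aromatic carbon would sit with compound 4 or with compound 3 remains open. Also open, from the compounds shown here alone, is how a plain phenyl without any substituent would compare with these four compounds.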